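The compounds below may be only part of what the source reports. "The series", "measured", "known", "first", "only" and "open" are said of these compounds alone.

Compound 1, `CC[C@H](C)[C@@H]1C(=O)N[C@H](C2Cc3ccccc3C2)C(=O)N1[C@@H](C(=O)N1CCOCC1)c1cnc(C)cc1C`, was examined in an ADME assay on the whole organism (plasma) for pharmacokinetics, with Rattus norvegicus as the target, at a dose of 5 mg/kg by the oral route (on this read-out lower numbers stand for lower exposure and higher numbers for higher exposure at the dose given), and gave 1110 ng.h/mL. Compound 2, `CC[C@H](C)[C@@H]1C(=O)N[C@H](C2Cc3ccccc3C2)C(=O)N1[C@@H](C(=O)N(C)C)c1cnc(C)cc1C`, is its counterpart with dimethylamino in place of morpholin-4-yl on a carbonyl carbon; in this assay compound 2 gave 2690 ng.h/mL, so the change produced a 2.4-fold higher number from compound 1 to compound 2 (0.38 log units; beyond the scatter).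

Compound 3, `COc1ccc([C@H](C(=O)N2CCOCC2)N2C(=O)[C@@H](C3Cc4ccccc4C3)NC(=O)[C@H]2CC(C)C)cn1`, rests on a different core from compound 1; the difference between the two cores is not broken down here. In this assay compound 3 gave 2130 ng.h/mL, a number that sits within the scatter of compound 2 and also within the scatter of compound 1, so no order among the three can be read from these values.

Compound 4, `COc1ccc([C@H](C(=O)N(C)C)N2C(=O)[C@@H](C3Cc4ccccc4C3)NC(=O)[C@H]2CC(C)C)cn1`, has not yet been measured. It differs from compound 3 by dimethylamino in place of morpholin-4-yl on a carbonyl carbon. Among the compounds with values here, this is the same change as the one between compound 1 and compound 2, made at a place described in the same words, and it appears twice among the four compounds. Because a 2.4-fold higher number from compound 1 to compound 2 (0.38 log units; beyond the scatter) was seen on the first core, a step of about the same size is expected on the core of compound 3, that is a 2.2-fold higher number from compound 3 to compound 4 (0.33 log units; beyond the scatter). Since that expectation rests on a single earlier pair, the range is kept wide. Compound 4 is therefore estimated to give 4600 ng.h/mL in this assay, with an expected span from 2200 ng.h/mL to 9500 ng.h/mL.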

Compound 4, area under the concentration-time curve in the Rattus norvegicus assay: 2230 ng.h/mL
Estimate against measurement, compound 4: 2.1-fold (0.31 log units) above; the measured number falls inside the stated range.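

In the Rattus norvegicus assay, where compound 3 gives 2130 ng.h/mL and compound 4 gives 2230 ng.h/mL, dimethylamino in place of morpholin-4-yl on a carbonyl carbon gave a 1.0-fold higher number from compound 3 to compound 4 (0.02 log units; within the scatter), while the same change on the core of compound 1 gave a 2.4-fold higher number from compound 1 to compound 2 (0.38 log units; beyond the scatter). Although only the second of these steps lies beyond the scatter, the two cannot be told apart: the same change on two cores in the Rattus norvegicus assay, a 2.4-fold higher number (0.38 log units; beyond the scatter) from compound 1 to compound 2 and a 1.0-fold higher number (0.02 log units; within the scatter) from compound 3 to compound 4, 2.3-fold (0.36 log units) apart, within the scatter of two such steps. The pairs therefore do not show that the change carries its effect from one core to the other, nor do they show that the effect depends on the core. Within the data shown here, in a physicochemical assay for solubility, read by HPLC (a higher number here means a more soluble compound, a lower number a less soluble compound), compound 3 gives 249 ug/mL and compound 4 gives 216 ug/mL; the only step available, a 1.2-fold lower number from compound 3 to compound 4 (0.06 log units; within the scatter), comes from the core of compound 3 alone and offers no second core for comparison.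

The compounds shown leave open whether the same change on a third core would give a step closer to the larger or the smaller of the two seen here, which more pairs would be needed to settle. They also leave open how exposure would respond to other groups on the carbonyl carbon, such as pyrrolidin-1-yl, piperidin-1-yl or a longer dialkylamino chain.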